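Solubility expected for compound 4 from the step at compound 2

The source may hold more compounds than are shown below. What is called first, only, known or untested is meant among the compounds shown, and "the series" means these compounds.

compound 1 `COC(=O)C1=C(C)NC(c2nccs2)=NC1(C)c1ccc(C#N)cc1`: 87 ug/mL
compound 2 `COC(=O)C1=C(CN2CCOCC2=O)NC(c2nccs2)=NC1(C)c1ccc(F)cc1`: 440 ug/mL
compound 3 `COC(=O)C1=C(CN2CCC(F)(F)CC2)NC(c2nccs2)=NC1(C)c1ccc(F)cc1`: a limit of the assay, < 1 ug/mL

In a physicochemical assay for solubility, read by HPLC, in phosphate buffer, at pH 6.5 (a higher number here means a more soluble compound, a lower number a less soluble compound), compound 2 stands highest of the two numbers, with compound 1 the nearest at a lower number. Compound 4 `COC(=O)C1=C(COCC(F)(F)F)NC(c2nccs2)=NC1(C)c1ccc(F)cc1` differs from compound 2 by 2,2,2-trifluoroethoxy in place of 3-oxomorpholin-4-yl on a saturated chain carbon bound to a double-bonded ring carbon. Among the compounds with values here, the only measured step at this place is an at least 440-fold lower number from compound 2 to compound 3 (2.64 log units; beyond the scatter), which ends at the limit of < 1 ug/mL in this assay, at which 1 of the 3 values shown sits. Within the data shown here, the group entering in compound 4 is not the one entering in compound 3, so that step is taken as a direction rather than a size: a fall beyond the scatter is expected, of about a 15-fold lower number from compound 2 to compound 4 (1.17 log units; beyond the scatter). Compound 4 is therefore estimated at 30 ug/mL, within a range from 5 ug/mL to 150 ug/mL.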

Compound 4, solubility: 19 ug/mL
The estimate for compound 4 lay 1.6-fold (0.20 log units) above the measured number, within the range that was stated.
By their numbers in this assay, from the lowest: compound 4; then compound 1; then compound 2. At a limit, below all of these: compound 3.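

In this assay, the place on a saturated chain carbon bound to a double-bonded ring carbon now has a second measured replacement for 3-oxomorpholin-4-yl, and the number again falls: a 23-fold lower number from compound 2 to compound 4 (1.36 log units; beyond the scatter). The two entering groups do not read alike, since 2,2,2-trifluoroethoxy in place of 4,4-difluoropiperidin-1-yl gives an at least 19-fold higher number from compound 3 to compound 4 (1.27 log units; beyond the scatter). That step starts from a limit and not a number: the limit of < 1 ug/mL in this assay, at which 1 of the 4 values shown sits.

The compounds shown leave open how a plain morpholin-4-yl, without the carbonyl, or a carboxylic acid would read at this place. They also leave open whether the fall follows from losing 3-oxomorpholin-4-yl or from what enters.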